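This account rests on a few compounds, and the source may have more. Where it says the series, first, only, none or still open, it means among the compounds named here.

Measured so far in a functional assay on CCRF-CEM cells (Homo sapiens) for cytotoxicity, read by cell counting, with a stated time of 3 days; on this read-out lower numbers stand for stronger inhibition and higher numbers for weaker inhibition:
compound 1 `CC(C)(C)c1ccc(CN2C(=O)S/C(=C\c3cccc(N)c3)C2=O)cc1`, 165000 nM
compound 2 `Nc1cccc(/C=C2\SC(=O)N(Cc3cccc(F)c3)C2=O)c1`, 250000 nM
compound 3 `Nc1cccc(/C=C2\SC(=O)N(Cc3ccc(C(F)(F)F)cc3)C2=O)c1`, > 250000 nM

Compound 3 stands at the weak end of the set; its value in this assay is a limit, not a number, as the limit of > 250000 nM in this assay, at which 1 of the 3 values shown sits, shows. Compound 4 `Nc1cccc(/C=C2\SC(=O)N(Cc3ccc(Cl)cc3)C2=O)c1` differs from compound 3 by chloro in place of trifluoromethyl on an aromatic carbon. Among the compounds with values here, the one measured step on this ring, an at least 1.5-fold higher number from compound 1 to compound 3 (0.18 log units; that floor lies within the scatter), is small and its floor lies within the scatter. Compound 2 shows only that a fluoro on that ring also gives a weak value. Within the data shown here, no step therefore points to a change in this assay beyond the scatter, and compound 4 is expected to sit near compound 3, that is around 230000 nM (range 120000 nM to 450000 nM), an estimated step of an at least 1.0-fold lower number from compound 3 to compound 4 (0.03 log units; that floor lies within the scatter) that may again come back as a limit.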

Compound 4, half-maximal inhibitory concentration: > 250000 nM
Compound 4: a limit, no number; the forecaster's own chance of this, stated with the estimate: 50%; at least 1.0-fold (0.03 log units) between middle value and limit.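

In this assay chloro on this aromatic carbon, para to a large group, gives a limit and not a number, so it joins trifluoromethyl at the same ceiling: the limit of > 250000 nM in this assay, at which 2 of the 4 values shown sit. The step of an at least 1.5-fold higher number from compound 1 to compound 4 (0.18 log units; that floor lies within the scatter) has the same floor as the one seen with trifluoromethyl, so the smaller chloro adds no readable change. The other readable step is a number no lower from compound 2 to compound 4 (the limit leaves the size open). The step from compound 3 to compound 4 cannot be read.

Going by these compounds, whether a hydroxyl or a methoxy group at this place gives a readable number remains open, as does any order among the groups that sit at the limit.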